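This account rests on a few compounds, and the source may have more. Where it says the series, first, only, none or still open, it means among the compounds named here.

In an ADME assay on Vero cells (Chlorocebus sabaeus) for cytotoxicity, with a stated time of 7 days (a lower number here means that less compound is tolerated, a higher number that more compound is tolerated), compound 1 `COc1ccc2[nH]c(C(=O)N3CC(=O)N(Cc4ccccc4)[C@@H](COC(C)(C)C)C3)cc2c1` gives 78200 nM as a true number. Compound 2 `COc1ccc2[nH]c(C(=O)N3CC(=O)N(Cc4ccccc4)[C@@H](CN4CCN(c5ccccn5)CC4)C3)cc2c1` stands at > 30000 nM in this assay and this is a limit, not a number. Going on to compound 3 `COc1ccc2[nH]c(C(=O)N3CC(=O)N(Cc4ccccc4)[C@@H](CN4CC5CCCCC5C4)C3)cc2c1`, the change is a group of 9 heavy atoms (8 carbon, 1 nitrogen; one five-membered non-aromatic ring with 1 hetero atom, one six-membered non-aromatic ring of carbon only) in place of a group of 12 heavy atoms (9 carbon, 3 nitrogen; one six-membered non-aromatic ring with 2 hetero atoms, one six-membered aromatic ring with 1 hetero atom), on a saturated chain carbon bound to a saturated ring carbon and the rest of the structure stays the same. Within the data shown here, only one measured step bears on this change: a step that the limit leaves unreadable from compound 1 to compound 2 has no size to carry over because of the limit of > 30000 nM in this assay, at which 1 of the 2 values shown sits, and it concerns the same place on the saturated chain carbon. No step beyond the scatter is therefore expected in this assay and the data give no direction. The estimated step is a step that the limit leaves unreadable from compound 2 to compound 3 and it is expected to stay small. For compound 3 the expected value is 40000 nM with an estimated range from 13000 nM to 100000 nM as its bounds.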

Compound 3, half-maximal cytotoxic concentration: 8200 nM
Beside the measured number, compound 3's estimate is 4.9-fold (0.69 log units) above it, outside the stated range (below it).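

In this assay, the group on the saturated chain carbon bound to a saturated ring carbon now shows a readable effect, with a 9.5-fold lower number from compound 1 to compound 3 (0.98 log units; beyond the scatter) and an at least 3.6-fold lower number from compound 2 to compound 3 (0.56 log units; beyond the scatter). Compound 3 is the least tolerated of the three in this assay, as both of its steps lie beyond the scatter. For compound 2 the value is a limit and not a number, and the step from compound 1 to compound 2 cannot be read: the limit of > 30000 nM in this assay, at which 1 of the 3 values shown sits.

The compounds shown do not tell whether the lower number of compound 3 goes with its six-membered non-aromatic ring of carbon only or with the absence of the 4-(pyridin-2-yl)piperazin-1-yl group. From the compounds shown here alone, how a plain piperidine, a morpholine or a carboxylic acid would read at this place remains open.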